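The compounds below may be only part of what the source reports. "The series", "measured", "known", "first", "only" and "open" are said of these compounds alone.

Working notes on the series, read in a physicochemical assay for solubility, read by LC-MS, using the shake flask method, measured as thermodynamic solubility, with a stated time of 24 h, at pH 6.5; on this read-out lower numbers stand for lower solubility and higher numbers for higher solubility. Going by the values given here, compound 2 `Cc1ccc(-c2cn(C[C@H]3O[C@H](CO)[C@@H](O)[C@H](O)[C@@H]3O)nn2)cc1` gives 1490 ug/mL, the only actual number in this set. Compound 1 `COc1ccc(Cn2cc(CO[C@H]3O[C@H](CO)[C@@H](O)[C@H](O)[C@@H]3O)nn2)cc1` reads > 3000 ug/mL, which is a limit and not a number. Compound 3 `OC[C@H]1O[C@H](Cn2cc(-c3cccc(Cl)c3)nn2)[C@@H](O)[C@@H](O)[C@@H]1O` reads > 3000 ug/mL, again a limit. The upper side of the data therefore stops at the limit of > 3000 ug/mL in this assay, at which 2 of the 3 values shown sit.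

Compound 4 `OC[C@H]1O[C@H](Cn2cc(-c3ccc(C(F)(F)F)cc3)nn2)[C@@H](O)[C@@H](O)[C@@H]1O` is not yet measured. Against compound 2 it carries trifluoromethyl in place of methyl on an aromatic carbon, para to a large group (trifluoromethyl in place of methyl on an aromatic carbon).

Among the compounds with values here, one measured step bears on this change: an at least 2.0-fold higher number from compound 2 to compound 3 (0.30 log units; that floor lies within the scatter). That step puts 3-chlorophenyl in place of 4-methylphenyl, its floor lies within the scatter, and it ends on a limit, so it fixes no true size and only a weak upward direction. No step beyond the scatter is therefore expected in this assay. The expected step is a 1.2-fold lower number from compound 2 to compound 4 (0.09 log units; within the scatter). For compound 4 the estimated value is 1200 ug/mL, with an expected range of 400 ug/mL to 3000 ug/mL.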

Compound 4, solubility: 525 ug/mL
Compound 4: the middle estimate sits 2.3-fold (0.36 log units) above what was measured; the measured number falls inside the stated range.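

In this assay, trifluoromethyl in place of methyl on an aromatic carbon, para to a large group, gives a 2.8-fold lower number from compound 2 to compound 4 (0.45 log units; beyond the scatter). Going by these compounds alone, this is the first step with a true number at both ends, so both its size and its direction can be read. Within the data shown here, the only earlier step on this ring is an at least 2.0-fold higher number from compound 2 to compound 3 (0.30 log units; that floor lies within the scatter); it ends on a limit and fixes no true size.

This single pair does not show whether the same drop would hold at another place on the ring, or how an amine or a carboxylic acid in place of methyl on this carbon would read. The top of the read-out also remains unresolved, and no order can be given among the compounds that sit there: the limit of > 3000 ug/mL in this assay, at which 2 of the 4 values shown sit.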